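Hydroxamic acid to ethoxy amide: stability notes

The source may report more compounds than this note shows. Statements on the series, on what has been measured and on what is new or still open speak of the compounds shown alone.

Measured in an ADME assay on microsomes from liver (Homo sapiens) for metabolic stability; a lower number here means that the compound disappears faster, a higher number that the compound lasts longer:
- Compound 1 `Cc1c(-c2ccc(-c3ccccc3F)cc2)nc2ccc(F)cc2c1C(N)=O`: 2.25 h
- Compound 2 `Cc1c(-c2ccc(-c3ccccc3F)cc2)nc2ccc(F)cc2c1C(=O)NO`: > 3 h

Compound 2 gives > 3 h, which is a limit and not a number (the limit of > 3 h in this assay, at which 1 of the 2 values shown sits). Compound 3 `CCONC(=O)c1c(C)c(-c2ccc(-c3ccccc3F)cc2)nc2ccc(F)cc12` carries ethyl in place of hydrogen on an oxygen, hydroxycarbamoyl to ethoxycarbamoyl (ethyl in place of hydrogen on an oxygen). Going by the values given here, the only measured step, an at least 1.3-fold higher number from compound 1 to compound 2 (0.12 log units; that floor lies within the scatter), sits on the amide-type nitrogen rather than this oxygen, so it sets no size for this change. No step beyond the scatter is expected in this assay, and the expected change is an at least 1.2-fold lower number from compound 2 to compound 3 (0.07 log units; that floor lies within the scatter). For compound 3 the estimate is 2.5 h (range 1.2 h to 4 h).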

Compound 3, half-life: > 3 h
Compound 3: no number, only a limit (the forecaster's own chance of this, stated with the estimate: 35%); middle value at least 1.2-fold (0.07 log units) away from the limit.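

Compound 3 gives a limit and not a number in this assay: the limit of > 3 h in this assay, at which 2 of the 3 values shown sit.

The size of the change from hydroxycarbamoyl to ethoxycarbamoyl cannot be read, as both ends are limits, but the ethoxy compound stays at the limit and does not fall to a measurable value. The comparison with the amide gives an at least 1.3-fold higher number from compound 1 to compound 3 (0.12 log units; that floor lies within the scatter), so a real gain is neither shown nor excluded.

On these data alone, the true half-lives of compound 2 and compound 3 remain open. Also open, as far as these compounds go, is whether a longer chain or an amine-bearing chain on that oxygen would stay at the limit.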